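Methoxy on the urea phenyl: expected effect in the series

The source may report more compounds than this note shows. Statements on the series, on what has been measured and on what is new or still open speak of the compounds shown alone.

Compound 1 `Cc1ccccc1NC(=O)Nc1cccc(CNc2ncnc3ccccc23)c1` gives 40200 nM in a functional assay on A549 cells (Homo sapiens) for antiproliferative activity, read by MTT assay; on this read-out higher numbers stand for weaker inhibition and lower numbers for stronger inhibition. Compound 2 `Cc1cccc(NC(=O)Nc2cccc(CNc3ncnc4ccccc34)c2)c1` gives 30200 nM in this assay; the step of a 1.3-fold lower number from compound 1 to compound 2 (0.12 log units; within the scatter) is within the scatter. Compound 3 `COc1cc2ncnc(NCc3cccc(NC(=O)Nc4ccccc4)c3)c2cc1OC` carries two methoxy groups on the shared core and an unsubstituted phenyl on the urea; in this assay compound 3 gives 17100 nM, the lowest of the three numbers, though its gap to compound 2 is within the scatter and only its gap to compound 1 is beyond it. Compound 3 differs from compound 1 and from compound 2 in more than one place, so these values say nothing about any single change.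

Compound 4 `COc1ccc(NC(=O)Nc2cccc(CNc3ncnc4cc(OC)c(OC)cc34)c2)cc1` differs from compound 3 by methoxy in place of hydrogen on an aromatic carbon. Among the compounds with values here, the only measured step that touches substitution on the urea phenyl is a 1.3-fold lower number from compound 1 to compound 2 (0.12 log units; within the scatter), a shift of a methyl group that stayed within the scatter; no measured step adds a methoxy to that ring. On this basis the step expected in this assay is a 1.1-fold lower number from compound 3 to compound 4 (0.06 log units; within the scatter), within the scatter and of no settled direction. For compound 4 the estimate in this assay is 15000 nM, with a range from 6000 nM to 40000 nM.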

Compound 4, half-maximal inhibitory concentration: 24500 nM
The estimate for compound 4 lay 1.6-fold (0.21 log units) below the measured number; the measured number falls inside the stated range.
By their numbers in this assay, from the lowest: compounds 3, 4, 2 and 1 (each within the scatter of the next, the first and the last beyond it).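

In this assay, within the data shown here, the change from phenyl to 4-methoxyphenyl on the urea gives a 1.4-fold higher number from compound 3 to compound 4 (0.16 log units; within the scatter), the first step that adds a group to this ring rather than moving one. A methoxy para to a large group on this ring therefore leaves the number indistinguishable from that of the unsubstituted phenyl, at least on the core carrying two methoxy groups, and no direction can be read from the step. No supporting data bear on this step or offer an explanation for it.

Going by these compounds, it stays open whether a different group at this place, such as an amine, a carboxylic acid or a longer alkoxy chain, would give a step beyond the scatter, or whether this ring tolerates substitution of any kind without a change in the number. It also stays open whether methoxy gives a step of the same size on the core of compound 2, which lacks the two methoxy groups, since the compounds shown hold no pair that tests this.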